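The source may report more compounds than this note shows. Statements on the series, on what has been measured and on what is new or still open speak of the compounds shown alone.

Measured compounds:
compound 1, `C[C@@H](NC(=O)c1ccc(C#Cc2cc(F)ccn2)cn1)C(C)(C)O`, efficacy 66.2%
compound 2, `C[C@@H](NC(=O)c1ccc(C#Cc2cccc(F)c2)nc1)C(C)(C)O`, efficacy 64.9%

In a functional assay on HEK293 cells for positive allosteric modulation of metabotropic glutamate receptor 5 (Rattus norvegicus), read by fluorescence and calcium flux (on this read-out higher numbers stand for larger maximal responses and lower numbers for smaller maximal responses), compound 1 reaches 66.2%. In this assay compound 2 reaches 64.9%. The two numbers lie within the usual scatter of each other, so no ranking between compound 1 and compound 2 can be read from them; compound 2 simply has the same kind of maximal response as compound 1.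

Compound 3, `Cc1nc(C#Cc2cccc(F)c2)ccc1C(=O)N[C@H](C)C(C)(C)O`, has not yet been measured. It differs from compound 2 in a single place: methyl in place of hydrogen on an aromatic carbon. The methyl sits on an aromatic carbon of the shared core, next to the ring nitrogen, as the difference above describes. Among the measured compounds shown here, no measured pair in this set shows what such a change does, so there is no step to lean on. With only compound 1 and compound 2 at hand, and both at a similar maximal response, the expectation for compound 3 is a step of a number 0.9 percentage points lower from compound 2 to compound 3 (within the scatter) that stays within the scatter, in no clear direction. Compound 3 is therefore estimated at 64%, with a range from 44% to 84%.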

Compound 3, largest response reached (reported as efficacy), in percent of the reference or control that the assay uses: 64.9%
For compound 3 the middle estimate is 0.9 percentage points below the measured one; low and high end bracket the measured number.
By their numbers in this assay, from the lowest: compounds 2, 3 and 1 (each within the scatter of the next).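

In this assay, methyl in place of hydrogen on an aromatic carbon of the shared core, next to the ring nitrogen, gives no change at the digits printed from compound 2 to compound 3 (within the scatter). Among the compounds shown here, this is the first pair in the set that differs in one place, and it shows that this carbon can carry one extra heavy atom while the maximal response stays of the same kind. Nothing at hand speaks to why the two compounds match.

Going by these compounds, a single methyl is only one small probe, so it remains open whether a larger or different group on this same carbon, such as an ethyl chain, a methoxy group or a chlorine atom, would also leave the maximal response of the same kind. On these data alone, it is also open whether the same methyl would give a similar result on the other aromatic carbons of the shared core, or on the core of compound 1, where the arrangement of the ring nitrogens is different.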